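This account rests on a few compounds, and the source may have more. Where it says the series, first, only, none or still open, it means among the compounds named here.

Measured compounds in an assay on cells for inhibition of Amine oxidase [flavin-containing] B (Homo sapiens), read by fluorescence, with stated times of 30 min and 15 min, tested at 1 uM; a lower number here means less inhibition, a higher number more inhibition at the concentration tested (going by the name of the read-out):
compound 1 `COc1ccc(OCCOc2ccc3[nH]c(=O)n(C(C)C)c3c2)cc1` — 15.5%
compound 2 `CC1(C)C(=O)Nc2ccc(OCc3ccc(Cl)c(Cl)c3)cc21` — 28.8%
compound 3 `CC1(C)C(=O)Nc2ccc(OCc3cccc(Cl)c3)cc21` — 21.1%

Compound 3 shares its core with compound 2 and differs from it only by a number 7.7 percentage points lower from compound 2 to compound 3 (within the scatter). For the measured compounds named here, on the numbers so far compound 3 sits with both neighbours inside the scatter: compound 1 lies nearest to it and compound 2 furthest, and neither gap is large enough to count as a real difference in this assay.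

The next compound, compound 4 `CC1(C)C(=O)Nc2ccc(OCc3ccc(F)cc3)cc21`, is not yet measured. It differs from compound 3 by 4-fluorophenyl in place of 3-chlorophenyl on a saturated chain carbon bound to an oxygen on an aromatic ring. Going by the values given here, the only measured step that bears on this change is the one on the same aromatic ring, a number 7.7 percentage points lower from compound 2 to compound 3 (within the scatter), which stayed within the scatter. Among the compounds with values here, no measured step tells how a fluorine in place of a chlorine, or a change of its place on the ring, shows in this assay. A step of the same size class is therefore expected, with no direction beyond the scatter.

Compound 4 is estimated at 20% in this assay, with a range from 8% to 32%. This estimate means a step of a number 1.1 percentage points lower from compound 3 to compound 4 (within the scatter), which is expected to stay inside the scatter.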

Compound 4, a percentage reported as inhibition, at one concentration (the size of the read-out at that concentration, not a potency): "not active" (no number reported)
Nothing numeric was reported for compound 4; the estimate stays without a comparison.
By their numbers in this assay, from the lowest: compounds 1, 3 and 2 (each within the scatter of the next, the first and the last beyond it).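

In this assay, for the compounds shown here, compound 4 is reported only as not active, without a number, so no step from compound 3 to compound 4 can be read. No measured evidence bears on this result.

The compounds shown leave open how 4-fluorophenyl in place of 3-chlorophenyl on the shared core shows numerically in this read-out.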